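The source may hold more compounds than are shown below. What is called first, only, known or untested is meant among the compounds shown, and "the series" means these compounds.

Among the measured compounds shown here, compound 2, `N#Cc1ccc(SCc2ncnc3c2ncn3[C@@H]2O[C@H](CO)[C@@H](O)[C@H]2O)cc1`, gives 81.3 nM in an assay on isolated protein for binding affinity to Equilibrative nucleoside transporter 1 (Homo sapiens) (a higher number here means a weaker inhibitor, a lower number a stronger inhibitor), the lowest of the two numbers so far and set against compound 1, `OC[C@H]1O[C@@H](n2cnc3c(CSc4ccccc4I)ncnc32)[C@H](O)[C@@H]1O`, which in this assay gives 282 nM. For the measured compounds named here, the one step on record, a 3.5-fold lower number from compound 1 to compound 2 (0.54 log units; beyond the scatter), concerns the whole aryl group on the sulfur and was modest. Compound 3, `OC[C@H]1O[C@@H](n2cnc3c(CSc4ccc(F)cc4)ncnc32)[C@H](O)[C@@H]1O`, differs from compound 2 by fluoro in place of cyano on an aromatic carbon, a smaller exchange at the same place. Going by the values given here, no measured step follows this exchange directly; the step from compound 1 to compound 2 only shows that the aryl substituent moves this assay to a modest degree. Compound 3 is therefore expected to land near compound 2, with a mild rise toward the higher number of compound 1 judged more likely than a fall, a step of a 1.8-fold higher number from compound 2 to compound 3 (0.27 log units; within the scatter). The estimate for compound 3 in this assay is 150 nM, within 50 nM to 450 nM.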

Compound 3, half-maximal inhibitory concentration: 158 nM
Compound 3: the middle estimate sits 1.1-fold (0.02 log units) below what was measured; the measured number falls inside the stated range.
By their numbers in this assay, from the lowest: compounds 2, 3 and 1 (each within the scatter of the next, the first and the last beyond it).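

In this assay, fluoro in place of cyano on the aromatic carbon para to a large group gives a 1.9-fold higher number from compound 2 to compound 3 (0.29 log units; within the scatter) and so shows that this place tolerates the loss of the nitrile, with its triple bond and hydrogen-bond acceptor, without a change beyond the scatter. The exchange of the whole aryl group gives a 1.8-fold lower number from compound 1 to compound 3 (0.25 log units; within the scatter) as well, which places compound 3 within the scatter of both other compounds, although those two lie beyond the scatter of each other. Nothing shown explains these numbers.

On these data alone, it stays open whether the iodo group itself or its place on the ring sets compound 1 apart, which a 4-iodophenyl group would address. As far as these compounds go, it also stays open how an amine or a carboxylic acid at this place would read.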